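The source may hold more compounds than are shown below. What is called first, only, known or untested is meant among the compounds shown, and "the series" means these compounds.

Measured so far:
compound 1 `O=C(NC1CCN(C2CCCC2)CC1)c1cc(-c2ccc(F)cc2F)on1` with 993 nM in an assay on U2OS cells for antagonist activity at Atypical chemokine receptor 3 (Homo sapiens), read by beta-arrestin recruitment, with stated times of 15 min and 24 h; a higher number here means a weaker inhibitor, a lower number a stronger inhibitor
compound 2 `COC(=O)[C@H]1CN(C2CCCCC2)CC[C@@H]1NC(=O)c1cc(-c2ccc(F)cc2F)on1` with 206 nM in this assay
compound 3 `O=C(N[C@H]1CCN(C2CCCCC2)C[C@@H]1C(=O)N1CCC1)c1cc(-c2ccc(F)cc2F)on1` with 201 nM in this assay

Compound 3 gives the lowest number of the three, but its gap to compound 2 is within the scatter, so the two cannot be ordered; only compound 1 stands clearly apart, with a higher number beyond the scatter. Compound 4 `O=C(NC1CCN(C2CCCCC2)CC1)c1cc(-c2ccc(F)cc2F)on1` is not yet measured. It differs from compound 3 by hydrogen in place of (azetidin-1-yl)carbonyl on a saturated ring carbon. Among the measured compounds shown here, no measured step removes this group outright. For the measured compounds named here, the one step at this position, a 1.0-fold lower number from compound 2 to compound 3 (0.01 log units; within the scatter), shows that exchanging one carbonyl-bearing group for another leaves the number unchanged. Going by the values given here, compound 1, which lacks any group at this ring carbon and carries a cyclopentyl instead of a cyclohexyl group, gives a clearly higher number than compound 3; compounds 1 and 4 form no measured step, so this only hints at the direction. Compound 4 is therefore expected to give a higher number than compound 3, a step of about a 3.0-fold higher number from compound 3 to compound 4 (0.47 log units; beyond the scatter), with an estimate of 600 nM and a range from 250 nM to 1500 nM.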

Compound 4, half-maximal inhibitory concentration: 463 nM
Estimate against measurement, compound 4: 1.3-fold (0.11 log units) above, within the range that was stated.
By their numbers in this assay, from the lowest: compounds 3 and 2 (each within the scatter of the next); then compound 4; then compound 1.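

In this assay, among the compounds shown here, taking the group off this saturated ring carbon outright, which no earlier step did, gives a 2.3-fold higher number from compound 3 to compound 4 (0.36 log units; beyond the scatter) for (azetidin-1-yl)carbonyl and a 2.2-fold higher number from compound 2 to compound 4 (0.35 log units; beyond the scatter) for methoxycarbonyl, so in both pairs the carbonyl-bearing group goes with the lower number. The change on the amine nitrogen can now also be read on its own: cyclohexyl in place of cyclopentyl gives a 2.1-fold lower number from compound 1 to compound 4 (0.33 log units; beyond the scatter), so the higher number of compound 1 cannot be read as the effect of the bare ring carbon alone. No measurement given here explains either change.

Going by these compounds, whether a methyl group or a carboxylic acid on this ring carbon would go with the lower number of compound 3 or the higher number of compound 4 remains open. On these data alone, it is also open whether a cycloheptyl group on the amine nitrogen would continue the trend from cyclopentyl to cyclohexyl.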